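A few compounds are considered here, and "the series" means these few. Any claim that something is new, unique, unknown or untested is made for them only; others in the source may bear on it.

Three compounds share one core and were tested in a functional assay for antagonist activity at P2X purinoceptor 7 (Homo sapiens); on this read-out higher numbers stand for weaker inhibition and lower numbers for stronger inhibition. Compound 1 `Cc1n[nH]c(CC(C)C)c1CCC(=O)NCc1ccc(F)cc1Cl` gives 100 nM. Within the data shown here, compound 2 `Cc1n[nH]c(C(F)(F)F)c1CCC(=O)NCc1ccc(F)cc1Cl` gives 12.6 nM, and the single measured step, a 7.9-fold lower number from compound 1 to compound 2 (0.90 log units; beyond the scatter), is the only one-place change recorded so far. Compound 3 `Cc1c[nH]nc1CCC(=O)NCc1ccc(F)cc1Cl` gives 398 nM, the highest of the three numbers, so on this read-out compound 3 is the weakest inhibitor in the set.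

The step now followed leads from compound 3 to compound 4 `Cc1cnn(C)c1CCC(=O)NCc1ccc(F)cc1Cl`. The change is 1,4-dimethyl-1H-pyrazol-5-yl in place of 4-methyl-1H-pyrazol-3-yl on a saturated chain carbon, two bonds along the chain from a carbonyl carbon. Among the measured compounds shown here, no measured step touches the part of the molecule that is altered here: the step from compound 1 to compound 2 changes a group on an aromatic carbon, not the saturated chain carbon two bonds along the chain from the carbonyl carbon, so it gives no direct guide. With nothing measured to lean on, a change of no clear direction is expected, and the estimated step of a 1.3-fold higher number from compound 3 to compound 4 (0.10 log units; within the scatter) is set close to the scatter. For compound 4 the expected value in this assay is 500 nM, with an estimated range from 120 nM to 2000 nM.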

Compound 4, half-maximal inhibitory concentration: 158 nM
The estimate for compound 4 lay 3.2-fold (0.50 log units) above the measured number; the range from low to high includes it.
By their numbers in this assay, from the lowest: compound 2; then compounds 1 and 4 (each within the scatter of the next); then compound 3.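

In this assay the swap gives a 2.5-fold lower number from compound 3 to compound 4 (0.40 log units; beyond the scatter) and so strengthens inhibition rather than losing it. The group on the saturated chain carbon therefore need not carry a hydrogen-bond donor: the entering 1,4-dimethyl-1H-pyrazol-5-yl has 0 hydrogen-bond donors where the leaving 4-methyl-1H-pyrazol-3-yl has 1, and activity survives the change. No measurement on hand explains why the number falls.

The swap adds a methyl and changes how the ring is attached in a single step, so the compounds shown cannot say which of the two accounts for the gain. Also open, going by these compounds, is whether an ethyl or a longer chain on the ring nitrogen would be accepted, and whether a trifluoromethyl like that of compound 2 would help on this ring.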